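This account rests on a few compounds, and the source may have more. Where it says the series, first, only, none or still open, it means among the compounds named here.

Measured so far in a functional assay on PANC-1 cells (Homo sapiens) for inhibition, read by MTT assay, with a stated time of 24 h, tested at 10 uM; a lower number here means less inhibition, a higher number more inhibition at the concentration tested (going by the name of the read-out):
Compound 1 `CC(C)=CCC1Cc2c(O)cc(=O)n(CCCO)c2CC1(C)C` gives 25.6%
Compound 2 `CC(C)=CCC/C(C)=C/CC1Cc2c(O)cc(=O)n(CCCO)c2CC1(C)C` gives 28.7%

Compound 2 holds the higher of the two numbers in this assay, with compound 1 nearest and within the scatter. Compound 3 `CC(C)=CCC/C(C)=C/COc1cc(=O)n(CCCO)c2c1CC(C/C=C(\C)CCC=C(C)C)C(C)(C)C2` differs from compound 2 by 3,7-dimethylocta-2,6-dien-1-yl in place of hydrogen on an oxygen on an aromatic ring. Going by the values given here, no measured step touches the oxygen on the aromatic ring; the one step available, a number 3.1 percentage points higher from compound 1 to compound 2 (within the scatter), adds a chain on a saturated chain carbon and stays within the scatter. Weight of this single step suggests a chain entering elsewhere is expected to give a step of a number 1.3 percentage points higher from compound 2 to compound 3 (within the scatter), nothing beyond the scatter. Compound 3 is estimated at 30%, between 15% and 45%.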

Compound 3, a percentage reported as inhibition, at one concentration (the size of the read-out at that concentration, not a potency): 15.8%
The estimate for compound 3 lay 14.2 percentage points above the measured number; the measured number falls inside the stated range.
By their numbers in this assay, from the lowest: compounds 3, 1 and 2 (each within the scatter of the next, the first and the last beyond it).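

Replacing hydroxy with (3,7-dimethylocta-2,6-dien-1-yl)oxy gives a number 12.9 percentage points lower from compound 2 to compound 3 (beyond the scatter) in this assay and is the first listed step beyond the scatter. The chain added on the saturated chain carbon gave only a number 3.1 percentage points higher from compound 1 to compound 2 (within the scatter) in the same assay, so the oxygen on the aromatic ring is a place where substitution changes the read-out. Nothing on hand accounts for this step.

On these data alone, whether methyl or 3-methylbut-2-en-1-yl on this oxygen would give a similar step remains open. So does the effect of an amine or a carboxylic acid at the end of a chain there.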